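This account rests on a few compounds, and the source may have more. Where it says the series, first, only, none or still open, it means among the compounds named here.

Measured so far in a physicochemical assay for lipophilicity; a lower number here means a more polar compound, a higher number a more lipophilic compound:
- compound 1 `C[C@H]1CC[C@@H]2[C@@H](OC(=O)[C@]23CC(c2ccc(Br)cc2)N(c2ccccc2)O3)[C@]2(C)C(=O)C=C[C@@]12O`: 4
- compound 2 `C[C@H]1CC[C@@H]2[C@@H](OC(=O)[C@]23CC(c2ccc(C#N)cc2)N(c2ccccc2)O3)[C@]2(C)C(=O)C=C[C@@]12O`: 2.94
- compound 3 `C[C@H]1CC[C@@H]2[C@@H](OC(=O)[C@]23CC(c2ccccc2F)N(c2ccccc2)O3)[C@]2(C)C(=O)C=C[C@@]12O`: 3.35

All three share one core and differ only in the aromatic ring on a saturated ring carbon. Compound 3, at 3.35, sits in the middle, and compound 2 is its nearest neighbour.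

The next structure is compound 4 `C[C@H]1CC[C@@H]2[C@@H](OC(=O)[C@]23CC(c2ccc([N+](=O)[O-])cc2)N(c2ccccc2)O3)[C@]2(C)C(=O)C=C[C@@]12O`, and the change is 4-nitrophenyl in place of 2-fluorophenyl on a saturated ring carbon. Among the measured compounds shown here, no measured compound carries this 4-nitrophenyl group, so the estimate has to lean on related swaps. For the measured compounds named here, three steps bear on it. The first is a number 1.06 log units lower from compound 1 to compound 2 (beyond the scatter), which shows that changing only the group on this aromatic ring can matter a great deal in this assay. The second is a number 0.65 log units lower from compound 1 to compound 3 (beyond the scatter). The third and closest is a number 0.41 log units higher from compound 2 to compound 3 (beyond the scatter), which replaces 4-cyanophenyl, taken here as the nearest measured match for 4-nitrophenyl, with 2-fluorophenyl. Run backwards, that last step points downward from compound 3, but the match is imperfect, so only part of it is likely to carry over.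

The expected result is a slight fall that stays inside the scatter, a number 0.20 log units lower from compound 3 to compound 4 (within the scatter). The estimate for compound 4 is 3.15, with an expected range of 2.8 to 3.5.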

Compound 4, partition coefficient: 3.15
Compound 4: the middle estimate sits on the measured number at the digits printed, and the stated range covers the measured number.
By their numbers in this assay, from the lowest: compounds 2, 4 and 3 (each within the scatter of the next, the first and the last beyond it); then compound 1.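

In this assay, the 4-nitrophenyl group adds a new pairing at this saturated ring carbon: the change from 2-fluorophenyl gives a number 0.20 log units lower from compound 3 to compound 4 (within the scatter), and nitro in place of cyano gives a number 0.21 log units higher from compound 2 to compound 4 (within the scatter). Among the compounds shown here, compound 4 therefore cannot be separated from either neighbour, even though compound 2 and compound 3 are separated from each other beyond the scatter, so it bridges a gap that the earlier compounds left open. Bromo, by contrast, still stands apart, with nitro in its place giving a number 0.85 log units lower from compound 1 to compound 4 (beyond the scatter), which makes nitro the second group after cyano to show a clear step away from compound 1 on the same aromatic carbon, although nothing measured here explains this grouping.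

The compounds shown leave open how far this assay's number would move with a group of a different kind on the same ring, such as an amine or a carboxylic acid in place of the nitro group. They also leave open whether a plain phenyl group at this saturated ring carbon would fall with compound 1 or with the other three.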